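The compounds below may be only part of what the source reports. "The series", "measured", "known", "first", "only" and "open" are said of these compounds alone.

Measured compounds in an ADME assay on BHK-21 cells (Mesocricetus auratus) for cytotoxicity, with a stated time of 3 days; a lower number here means that less compound is tolerated, a higher number that more compound is tolerated:
Compound 1 `O=C(CCSc1nnc(-c2ccncc2)s1)Nc1ccccc1` gives > 50000 nM, which is a limit of the assay and not a number.
Compound 2 `O=C(CCSc1nnc(-c2ccncc2)s1)Nc1ccc(Cl)cc1Cl` gives > 50000 nM, likewise a limit.
Compound 3 `O=C(CCSc1nnc(-c2ccncc2)s1)NCc1ccccc1` gives 18700 nM.

Compound 1 thus stands at the top of what this assay reports, at the limit where two of the three values sit (the limit of > 50000 nM in this assay, at which 2 of the 3 values shown sit). Only compound 3 gives an actual number. Compound 4 `CC(CSc1nnc(-c2ccncc2)s1)C(=O)Nc1ccccc1` differs from compound 1 by methyl in place of hydrogen on a saturated chain carbon bound to a carbonyl carbon and a saturated chain carbon, a change on the chain rather than on the amide nitrogen. All three measured steps alter the group on the amide-type nitrogen instead: a step that the two limits leave unreadable from compound 1 to compound 2, an at least 2.6-fold lower number from compound 1 to compound 3 (0.42 log units; beyond the scatter) and an at least 2.6-fold lower number from compound 2 to compound 3 (0.42 log units; beyond the scatter). On these data alone, none of them touches the chain, so they bear on the present change only loosely; they show that swapping the aryl group for benzyl lowers the number, while the chain itself remains untested. Given that compound 1 sits at the limit, the expected step is a number no higher from compound 1 to compound 4 (the limit leaves the size open), or none beyond the scatter. Compound 4 is therefore estimated at 50000 nM, within 20000 nM to 150000 nM, with a good chance that this assay again reports only a limit.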

Compound 4, half-maximal cytotoxic concentration: > 50000 nM
Compound 4 was reported as a limit (the forecaster's own chance of this, stated with the estimate: 65%); the middle value sits exactly at the limit.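

Compound 1 and compound 4 each end at a limit of the assay, not a number, so no step between them can be read: the limit of > 50000 nM in this assay, at which 3 of the 4 values shown sit.

The compounds shown leave open whether methyl in place of hydrogen on this saturated chain carbon changes the tolerated concentration at all in this assay.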